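Swapping the Anilide Ring: Expected Cell Tolerance of Compound 3

The source may report more compounds than this note shows. Statements on the series, on what has been measured and on what is new or still open speak of the compounds shown alone.

Among the compounds with values here, compound 2 `O=C(CSc1snnc1-c1ccc(Br)cc1Br)Nc1ccc(Cl)cc1` is the only member of this small set with a measured number in an ADME assay on MT4 cells (Homo sapiens) for cytotoxicity, read by MTT assay, with a stated time of 5 days (a higher number here means that more compound is tolerated, a lower number that less compound is tolerated), where compound 2 gives 23300 nM. Compound 1 `Cc1ccc(NC(=O)CSc2snnc2-c2ccc(Br)cc2Br)c([N+](=O)[O-])c1` gives > 229000 nM, which is a limit of the method rather than a number (the limit of > 229000 nM in this assay, at which 1 of the 2 values shown sits). Compound 3 `Cc1ccc(NC(=O)CSc2snnc2-c2ccc(Br)cc2Br)c(Br)c1` has not been tested; it differs from compound 2 by 2-bromo-4-methylphenyl in place of 4-chlorophenyl on an amide-type nitrogen. Within the data shown here, no measured step covers this change, so the expected step of a 2.6-fold higher number from compound 2 to compound 3 (0.41 log units; beyond the scatter) in this assay is only a guess, leaning upward and modest in size. Compound 3 is therefore estimated at 60000 nM, within 20000 nM to 229000 nM.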

Compound 3, half-maximal cytotoxic concentration: > 216000 nM
Compound 3: no number, only a limit; the forecaster's own chance of this, stated with the estimate: 30%; at least 3.6-fold (0.55 log units) between middle value and limit.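

In this assay, within the data shown here, putting 2-bromo-4-methylphenyl in place of 4-chlorophenyl on an amide-type nitrogen gives an at least 9.2-fold higher number from compound 2 to compound 3 (0.96 log units; beyond the scatter), the first measured step for a change at this place. The value for compound 3 is a limit of the assay, not a number: the limit of > 216000 nM in this assay, at which 1 of the 3 values shown sits. The step from compound 1 to compound 3, bromo in place of nitro on an aromatic carbon, cannot be read.

Bromo and methyl enter together, and the compounds shown do not separate what each contributes. On these data alone, how a phenyl ring carrying an amine or a carboxylic acid would behave in this assay also stays open.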